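The compounds below may be only part of what the source reports. "The series", "measured", "known", "first", "only" and "open" are said of these compounds alone.

Compound 1 `O=C(N/N=C/c1ccc(Cl)cc1)c1cccnc1Nc1cccc(C(F)(F)F)c1` gives 48.5% in a functional assay on the whole organism (strain Wistar) for inhibition, with Rattus norvegicus as the target, read by paw edema, with a stated time of 3 h, at a dose of 10 mg/kg by the intraperitoneal route; a higher number here means more inhibition at the dose given (going by the name of the read-out), a lower number less inhibition. Compound 2 `COc1ccc(/C=N/NC(=O)c2cccnc2Nc2cccc(C(F)(F)F)c2)cc1` gives 26.5% in this assay; the step of a number 22 percentage points lower from compound 1 to compound 2 (beyond the scatter) goes with the change (methoxy in place of chloro on an aromatic carbon). Compound 3 `CNc1ncccc1C(=O)N/N=C/c1cccc(Cl)c1` gives 39.6% in this assay, and compound 3 and compound 1 lie within the scatter of each other there. The difference between the core of compound 3 and the core of compound 1 is not broken down here. Compound 4 `CNc1ncccc1C(=O)N/N=C/c1cccc(OC)c1` is not yet measured; it differs from compound 3 by methoxy in place of chloro on an aromatic carbon, the second occurrence of methoxy in place of chloro on an aromatic carbon among these compounds. The two places are not the same word for word: in compound 2 the new group sits para to a large group, in compound 4 meta to a large group, so this is the same kind of change, not the same change. Going by the values given here, for compound 4 a step of about a number 18.6 percentage points lower from compound 3 to compound 4 (beyond the scatter) is expected in this assay, of the same sign as the measured one, because a number 22 percentage points lower from compound 1 to compound 2 (beyond the scatter) is the only measured instance of this change, while the different place around it argues for a somewhat smaller size. Compound 4 is accordingly estimated at 21% in this assay, between 8% and 34%.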

Compound 4, a percentage reported as inhibition, in the whole organism at one dose (the size of the read-out at that dose, not a potency): 49.5%
For compound 4 the middle estimate is 28.5 percentage points below the measured one, outside the stated range (above it).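

In this assay, methoxy in place of chloro on the core of compound 3 gives a number 9.9 percentage points higher from compound 3 to compound 4 (within the scatter), so the clear drop seen with this change on the core of compound 1 does not carry over to this second core. The two steps differ, and the change cannot be treated as having one transferable size across this series: the same change on two cores in this assay, a number 22 percentage points lower (beyond the scatter) from compound 1 to compound 2 and a number 9.9 percentage points higher (within the scatter) from compound 3 to compound 4, 31.9 percentage points apart, beyond the scatter of two such steps The comparison does not show that the core alone accounts for the gap, as the new group sits para to a large group in compound 2 and meta to a large group in compound 4, and each step rests on a single pair of compounds at one dose.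

Still open, on these data alone, is whether methoxy and chloro would behave alike on the two cores if both were placed the same way, which would separate the place from the core. Also open, as far as these compounds go, is how an amine or a carboxylic acid on an aromatic carbon of that ring would read in this assay.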